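Thiophen-2-yl replaces 2-methoxyphenyl in compound 3

The source may hold more compounds than are shown below. What is called first, only, known or untested is meant among the compounds shown, and "the series" means these compounds.

Among the compounds with values here, in a functional assay on HCT-116 cells (Homo sapiens) for inhibition, read by sulforhodamine B assay, with a stated time of 48 h, tested at 50 uM (on this read-out higher numbers stand for more inhibition of growth at the one concentration tested and lower numbers for less inhibition of growth), compound 1 `COc1cccc(/C=C/C(=O)/C=C/c2ccc(OCc3cn(CCCCOc4cc(=O)oc5ccccc45)nn3)c(OC)c2)c1` gives 44% and compound 2 `COc1ccccc1/C=C/C(=O)/C=C/c1ccc(OCc2cn(CCCCOc3cc(=O)oc4ccccc34)nn2)c(OC)c1` gives 43%, so compound 2 stands within the scatter of the only other measured compound. Compound 3 `COc1cc(/C=C/C(=O)/C=C/c2cccs2)ccc1OCc1cn(CCCCOc2cc(=O)oc3ccccc23)nn1` carries thiophen-2-yl in place of 2-methoxyphenyl on a double-bonded chain carbon bound to a double-bonded chain carbon. Within the data shown here, the one measured step, a number 1 percentage points lower from compound 1 to compound 2 (within the scatter), changes the same place but only exchanges 3-methoxyphenyl for 2-methoxyphenyl, so it bears only loosely on this swap. The estimated step, a number 1 percentage points lower from compound 2 to compound 3 (within the scatter), is expected to stay within the scatter, with no favoured direction. Compound 3 is expected at 42%, within an estimated range of 28% to 56%.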

Compound 3, percent growth inhibition at one concentration: 41%
Compound 3: the middle estimate sits 1 percentage points above what was measured; low and high end bracket the measured number.
By their numbers in this assay, from the lowest: compounds 3, 2 and 1 (each within the scatter of the next).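

Within the data shown here, on a double-bonded chain carbon bound to a double-bonded chain carbon, the earlier compounds exchanged only one methoxyphenyl for another, while thiophen-2-yl replaces the whole group with a five-membered aromatic ring of 5 heavy atoms. Even so, this assay shows a number 2 percentage points lower from compound 2 to compound 3 (within the scatter) and a number 3 percentage points lower from compound 1 to compound 3 (within the scatter) at this place, so all three groups read alike. Nothing available explains this outcome.
Still open, as far as these compounds go, is how an amine or a carboxylic acid on the ring at this place would read, or a pyridine ring in place of thiophen-2-yl.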